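This account rests on a few compounds, and the source may have more. Where it says the series, first, only, none or still open, it means among the compounds named here.

Compound 1 has the structure `CC(C)C(NC(=O)NO)C(=O)NC1CCCC1`. In a functional assay on WI-38 cells (Homo sapiens) for inhibition (on this read-out higher numbers stand for weaker inhibition and lower numbers for stronger inhibition), compound 1 gives > 100000 nM, which is a limit of the assay rather than a number. Compound 3, with the structure `CC(C)C(NC(=O)n1nnc2ccccc21)C(=O)NC1CCCCC1`, is built on a different core, and how that core differs from the core of compound 1 is not broken down here. In this assay compound 3 gives >= 100000 nM, also a limit. Compound 2 has the structure `CCC(C)C(NC(=O)n1nnc2ccccc21)C(=O)NC1CCCCC1`. In this assay compound 2 gives > 100000 nM, again a limit. The change from compound 3 to compound 2 is methyl in place of hydrogen on a saturated chain carbon, three bonds along the chain from an amide-type nitrogen and a carbonyl carbon, and the step it makes, a step that the two limits leave unreadable from compound 3 to compound 2, cannot be read, because the limit of > 100000 nM in this assay, at which 2 of the 3 values shown sit, and the limit of >= 100000 nM in this assay, at which 1 of the 3 values shown sits, together cover all three values shown.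

Compound 4, with the structure `CCC(C)C(NC(=O)NO)C(=O)NC1CCCC1`, has not yet been measured. It stands to compound 1 as compound 2 stands to compound 3, through the same change, (methyl in place of hydrogen on a saturated chain carbon, three bonds along the chain from an amide-type nitrogen and a carbonyl carbon), at a place described in the same words.

The step from compound 1 to compound 4 is expected to be a step that the limit leaves unreadable from compound 1 to compound 4, and this expectation rests on compound 1 giving only the limit > 100000 nM and on the earlier step being unreadable. Compound 4 is therefore estimated to give about 150000 nM in this assay, with a plausible range from 50000 nM to 500000 nM, most likely reported once more as a limit.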

Compound 4, half-maximal inhibitory concentration: > 100000 nM
Compound 4: a limit, no number (the forecaster's own chance of this, stated with the estimate: 85%); the middle value lies beyond the limit too.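

In this assay compound 4 gives > 100000 nM, a limit and not a number. No step can be read from compound 1 to compound 4 because both values sit at the same limit: the limit of > 100000 nM in this assay, at which 3 of the 4 values shown sit.

The compounds shown leave open how strongly any of them inhibits in this assay, and whether methyl in place of hydrogen at this place changes inhibition at all.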